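Working notes: amine replacement on the piperidine ring carbon

The compounds below may be only part of what the source reports. "The series", "measured", "known", "first", "only" and "open" are said of these compounds alone.

Compound 1 `O=S(=O)(NCC1CCN(CCCc2c[nH]c3ccc(-n4cnnc4)cc23)CC1)c1ccccc1` sits at the low end of the three numbers in hand: in an assay on CHO cells for displacement of a labelled ligand from 5-hydroxytryptamine receptor 1B (Homo sapiens) (on this read-out lower numbers stand for stronger inhibition and higher numbers for weaker inhibition), compound 1 gives 60 nM. Compound 3 `OC[C@H](NC1CCN(CCCc2c[nH]c3ccc(-n4ccnc4)cc23)CC1)c1ccccc1` gives 100 nM, a gap that lies within the scatter, so no order between compound 1 and compound 3 is claimed. Compound 2 `c1ccc(C2CCCCN2C2CCN(CCCc3c[nH]c4ccc(-n5cnnc5)cc34)CC2)cc1` gives 410 nM, a gap beyond the scatter. Compound 4 `c1cc(CNC2CCN(CCCc3c[nH]c4ccc(-n5cnnc5)cc34)CC2)co1` has not been run; it differs from compound 1 by ((furan-3-yl)methyl)amino in place of ((phenylsulfonyl)amino)methyl on a saturated ring carbon. For the measured compounds named here, no single-change pair is on hand to calibrate this move; compound 3, which also carries an amine substituent on that ring carbon, suggests that such a change need not cost much. The step from compound 1 to compound 4 is expected to be small, a 2.0-fold higher number from compound 1 to compound 4 (0.30 log units; within the scatter), toward a slightly higher number. Compound 4 is estimated at 120 nM, plausibly between 40 nM and 350 nM.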

Compound 4, half-maximal inhibitory concentration: 78 nM
Beside the measured number, compound 4's estimate is 1.5-fold (0.19 log units) above it; low and high end bracket the measured number.
By their numbers in this assay, from the lowest: compounds 1, 4 and 3 (each within the scatter of the next); then compound 2.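

For the compounds shown here, this is the first single-change pair at this saturated ring carbon: ((furan-3-yl)methyl)amino in place of ((phenylsulfonyl)amino)methyl gives a 1.3-fold higher number from compound 1 to compound 4 (0.11 log units; within the scatter) in this assay, so no order between the two compounds is claimed. Here, the sulfonyl group and the six-membered aromatic ring of carbon can both leave without a step beyond the scatter. Nothing on hand explains the size of this step.

Still open, as far as these compounds go, is whether a carboxylic acid on the furan ring would leave the number in this assay within the scatter. A longer chain between the amine and the furan ring is equally untested by the compounds shown.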